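This account rests on a few compounds, and the source may have more. Where it says the series, first, only, none or still open, it means among the compounds named here.

Two cores are in hand. Compound 1 `Cc1cc2c(cc1C(=O)N=C(N)N)S(=O)(=O)C(C)(C)C2(C)O` and compound 2 `Cc1cc2c(cc1C(=O)N=C(N)N)S(=O)(=O)C(C)(C)C2C` share one; compound 3 `N=C(N)NC(=O)c1ccc2c(c1)S(=O)(=O)CC2O` and the unmeasured compound 4 `N=C(N)NC(=O)c1ccc2c(c1)S(=O)(=O)CC2` share the other. How the core of compound 1 differs from that of compound 3 is not broken down here. In an assay on cells for inhibition of sodium/hydrogen exchanger (Oryctolagus cuniculus) (a lower number here means a stronger inhibitor, a higher number a weaker inhibitor), compound 1 gives 17 nM, compound 2 gives 14 nM and compound 3 gives 1500 nM.

The change from compound 1 to compound 2 is hydrogen in place of hydroxy on a saturated ring carbon and gives a 1.2-fold lower number from compound 1 to compound 2 (0.08 log units; within the scatter). The change from compound 3 to compound 4 is hydrogen in place of hydroxy on a saturated ring carbon. The places differ in one respect: in compound 1 the carbon is next to the ring atom that bears two methyl groups, in compound 3 it is not, so the change is of the same kind, not the same. Within the data shown here, the step of a 1.2-fold lower number from compound 1 to compound 2 (0.08 log units; within the scatter) lay within the scatter, which is the only guide here. Compound 4 is therefore expected to show an estimated step of a 1.2-fold lower number from compound 3 to compound 4 (0.06 log units; within the scatter). The estimate for compound 4 is 1300 nM, expected between 500 nM and 3500 nM.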

Compound 4, half-maximal inhibitory concentration: 790 nM
The estimate for compound 4 lay 1.6-fold (0.22 log units) above the measured number; the measured number falls inside the stated range.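

In this assay, hydrogen in place of hydroxy on the saturated ring carbon gives a 1.9-fold lower number from compound 3 to compound 4 (0.28 log units; within the scatter), so the step also stays within the scatter on this second core. The two cores agree on this change: the same change on two cores in this assay, a 1.2-fold lower number (0.08 log units; within the scatter) from compound 1 to compound 2 and a 1.9-fold lower number (0.28 log units; within the scatter) from compound 3 to compound 4, 1.6-fold (0.19 log units) apart, within the scatter of two such steps. This shows that the change carried from one core to the other as a step within the scatter, but it rests on two pairs only and does not show that the same would hold on a further core.

Open, going by these compounds, is what other groups, such as an amine, a methoxy group or fluorine, would do at this ring carbon on either core. Also open is which feature of the cores separates them, as no pair shown differs between them in one place.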